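Swapping a methoxy for chloro on a chalcone-like scaffold

This account rests on a few compounds, and the source may have more. Where it says the series, first, only, none or still open, it means among the compounds named here.

Compound 2 `COc1ccc(C(=O)/C=C/c2cc(-c3cc(OC)c(OC)c(OC)c3)n[nH]2)cc1` was tested in a functional assay on MCF7 cells (Homo sapiens) for inhibition, read by MTT assay, with a stated time of 48 h (a lower number here means a stronger inhibitor, a higher number a weaker inhibitor), where compound 2 gives 810 nM. Among the two compounds measured so far this is the higher number, but only within the scatter of its one neighbour: compound 1 `COc1ccc(C(=O)/C=C/c2cc(-c3cc(OC)c(OC)c(OC)c3)n[nH]2)cc1OC`, which in this assay gives 510 nM. Within the data shown here, the single measured step, a 1.6-fold higher number from compound 1 to compound 2 (0.20 log units; within the scatter), therefore shows no real shift.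

Compound 3 `COc1cc(-c2cc(/C=C/C(=O)c3ccc(Cl)cc3)[nH]n2)cc(OC)c1OC` has not yet been measured. It differs from compound 2 by a single exchange: chloro in place of methoxy on an aromatic carbon. Among the measured compounds shown here, the only step on record, a 1.6-fold higher number from compound 1 to compound 2 (0.20 log units; within the scatter), removed a methoxy from the same six-membered carbon ring and left the number essentially unchanged. It does not involve a chloro, so it bears on the present change only loosely, yet it suggests that edits on this ring produce small effects. For the measured compounds named here, no step here shows what a chloro does.

The expectation for compound 3 is therefore a step of a 1.2-fold lower number from compound 2 to compound 3 (0.06 log units; within the scatter), nothing beyond the scatter. Compound 3 is estimated at 700 nM, with a likely range from 300 nM to 1800 nM.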

Compound 3, half-maximal inhibitory concentration: 11600 nM
Beside the measured number, compound 3's estimate is 17-fold (1.22 log units) below it; the whole stated range lies below it.
By their numbers in this assay, from the lowest: compounds 1 and 2 (each within the scatter of the next); then compound 3.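

In this assay, 4-chlorophenyl in place of 4-methoxyphenyl gives a 14-fold higher number from compound 2 to compound 3 (1.16 log units; beyond the scatter) and so marks this place, para to a large group, as far less forgiving than the earlier edit on the same ring implied. Only a 1.6-fold higher number from compound 1 to compound 2 (0.20 log units; within the scatter) came from taking away a methoxy while keeping the one at this place, so the ring as a whole does not respond evenly to change: what sits para to the large group matters much more in this series than that first step could reveal. The wider exchange of 3,4-dimethoxyphenyl for 4-chlorophenyl gives a 23-fold higher number from compound 1 to compound 3 (1.36 log units; beyond the scatter) and lands in the same large range, with no measurement at hand that accounts for the size of the jump.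

As far as these compounds go, whether the rise follows the loss of the methoxy or the arrival of the chloro stays open, since compound 3 changes both at once. A plain hydrogen at this place would begin to separate the two, and a hydroxyl, an amine or a longer ether chain such as ethoxy would show how much of the methoxy this place needs.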